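Working notes: fluoro in place of methoxy

The source may hold more compounds than are shown below. What is called first, only, known or untested is meant among the compounds shown, and "the series" means these compounds.

Measured so far in a functional assay on DU-145 cells (Homo sapiens) for cytotoxicity, read by trypan blue exclusion, with a stated time of 96 h (a lower number here means a stronger inhibitor, a higher number a weaker inhibitor), as follows:
- compound 1 `COc1cc(OC)c(/C=C/S(=O)(=O)Cc2ccc(F)c(N)c2)c(OC)c1` gives 2500 nM
- compound 2 `COc1cc(OC)c(/C=C/S(=O)(=O)Cc2ccc(OC)c([N+](=O)[O-])c2)c(OC)c1` gives 2500 nM

Compound 2 stands level with compound 1 at the digits reported, within the usual scatter. Among the compounds with values here, these two compounds differ in more than one place on the shared core, so no single-place step has been measured.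

The next entry is compound 3 `COc1cc(OC)c(/C=C/S(=O)(=O)Cc2ccc(F)c([N+](=O)[O-])c2)c(OC)c1`, which differs from compound 2 by fluoro in place of methoxy on an aromatic carbon, ortho to a nitro group and para to a large group (fluoro in place of methoxy on an aromatic carbon). It shares its fluoro with compound 1 and its nitro group with compound 2.

Both of those neighbours sit at one level, compound 1 at 2500 nM and compound 2 at 2500 nM in this assay, so no direction is favoured. The estimated step of a 1.3-fold lower number from compound 2 to compound 3 (0.10 log units; within the scatter) is expected to stay within the scatter, although two compounds give only weak support and the range is kept wide.

For compound 3 the expected value is 2000 nM with an estimated range from 400 nM to 8000 nM as a working figure.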

Compound 3, half-maximal inhibitory concentration: 25000 nM
For compound 3 the middle estimate is 13-fold (1.10 log units) below the measured one, outside the stated range (above it).
By their numbers in this assay, from the lowest: compounds 1 and 2 (each within the scatter of the next); then compound 3.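

In this assay the fluoro in place of methoxy on an aromatic carbon, ortho to a nitro group and para to a large group, is not a silent change, with a 10-fold higher number from compound 2 to compound 3 (1.00 log units; beyond the scatter) at this position. Nitro in place of amino on an aromatic carbon leads to the same compound, with a 10-fold higher number from compound 1 to compound 3 (1.00 log units; beyond the scatter) beyond the scatter as well, so each of the two groups in compound 3 makes a clear difference while the other stays fixed, which the level values of compound 1 and compound 2 gave no sign of. Nothing available on these compounds accounts for either step.

Going by these compounds, it remains open whether fluoro in place of methoxy gives a step of similar size when an amino group stands in place of the nitro group, so the two steps cannot yet be called general for the series. Also open, on these data alone, is how a chloro or a hydroxyl group at this same aromatic carbon, ortho to a nitro group, would compare with methoxy and with fluoro.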